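Adding a Hydroxy Group to Compound 3

This account rests on a few compounds, and the source may have more. Where it says the series, first, only, none or still open, it means among the compounds named here.

Among the measured compounds shown here, compound 3 `N=C(NCc1ccccc1)[C@@H]1CCC(=O)N1Cc1ccc(F)cc1` gives 13.3% in a functional assay on SH-SY5Y cells (Homo sapiens) for cytotoxicity, read by MTT assay, with stated times of 8 h, 30 min and 12 h, tested at 0.05 uM (on this read-out higher numbers stand for a stronger effect at the one concentration tested and lower numbers for a weaker effect), the lowest of the three numbers measured so far. Its nearest neighbour is compound 1 `N=C(NCc1ccc(O)cc1)[C@@H]1CCC(=O)N1Cc1ccccc1[N+](=O)[O-]`, which gives 20%, a gap that lies within the scatter; the furthest is compound 2 `N=C(NCc1ccc(O)cc1)[C@@H]1CCC(=O)N1Cc1ccc([N+](=O)[O-])cc1`, which gives 25.9%, a gap beyond it. For the measured compounds named here, the only measured step, a number 5.9 percentage points higher from compound 1 to compound 2 (within the scatter), concerns a different part of the molecule. Compound 4 `N=C(NCc1ccc(O)cc1)[C@@H]1CCC(=O)N1Cc1ccc(F)cc1` differs from compound 3 by hydroxy in place of hydrogen on an aromatic carbon. Going by the values given here, no measured pair shows this particular change, so nothing in the data points to a step in either direction beyond the scatter. Compound 4 is therefore expected to give about 16%, with a range from 8% to 26%, which means an expected step of a number 2.7 percentage points higher from compound 3 to compound 4 (within the scatter).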

Compound 4, a percentage reported as activity, at one concentration (the size of the read-out at that concentration, not a potency): 35.2%
Beside the measured number, compound 4's estimate is 19.2 percentage points below it; the whole stated range lies below it.
By their numbers in this assay, from the lowest: compounds 3, 1, 2 and 4 (each within the scatter of the next, the first and the last beyond it).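

Among the compounds shown here, changing benzyl to 4-hydroxybenzyl gives a number 21.9 percentage points higher from compound 3 to compound 4 (beyond the scatter) in this assay and so shows that this position can move the read-out, which no earlier pair could show. With the 4-hydroxybenzyl group kept, fluoro in place of nitro gives a number 9.3 percentage points higher from compound 2 to compound 4 (within the scatter) and 4-fluorophenyl in place of 2-nitrophenyl gives a number 15.2 percentage points higher from compound 1 to compound 4 (beyond the scatter) as the second reading of that change at the other end of the molecule. No evidence is available to explain the rise with hydroxy. As far as these compounds go, whether hydroxy itself is needed stays open, since a methoxy group, an amine or a carboxylic acid at this position would be required to tell.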